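A few compounds are considered here, and "the series" means these few. Any claim that something is new, unique, unknown or untested is made for them only; others in the source may bear on it.

Measured compounds:
- compound 1, `Cc1ccc(OCC(=O)N(Cc2cccs2)c2cccnc2)cc1`: 198 nM
- compound 2, `CCN(Cc1cccs1)C(=O)COc1ccc(F)cc1`: 422 nM
- compound 3, `CCN(Cc1cccs1)C(=O)c1cc2cc(C)ccc2o1`: 120 nM

Of the compounds shown here, three have been tested in an assay on HEK293 cells for agonist activity at transient receptor potential cation channel subfamily M member 8 (Homo sapiens), read by fluorescence and calcium flux, with a stated time of 15 min; a higher number here means that more compound is needed for the effect, a lower number that less compound is needed. Compound 2 gives the highest number of the three: in this assay compound 2 gives 422 nM, while compound 1 gives 198 nM and compound 3 gives 120 nM, both lower by more than the usual scatter. Compound 1 and compound 3 lie within the scatter of each other, so no order between them is claimed.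

Compound 4, `CCN(Cc1cccs1)C(=O)COc1ccccc1`, is the next compound to be tested. It differs from compound 2 in one place: hydrogen in place of fluoro on an aromatic carbon. Going by the values given here, no measured pair shows this same change, so the size of the step is not known from the data. The step from compound 2 to compound 4 is expected to be small, most likely within the scatter, with a slight lean toward a higher number. The expected value for compound 4 in this assay is 550 nM, with a range from 220 nM to 1400 nM, which amounts to an expected step of a 1.3-fold higher number from compound 2 to compound 4 (0.12 log units; within the scatter).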

Compound 4, half-maximal effective concentration: 1400 nM
The estimate for compound 4 lay 2.5-fold (0.41 log units) below the measured number; measured number inside the range.
By their numbers in this assay, from the lowest: compounds 3 and 1 (each within the scatter of the next); then compound 2; then compound 4.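

In this assay, the position on the aromatic carbon para to a large group proves sensitive: exchanging fluoro for hydrogen gives a 3.3-fold higher number from compound 2 to compound 4 (0.52 log units; beyond the scatter). Going by these compounds alone, the earlier compounds gave no measured pair for this change, so this is the first sign that the position responds to it. The change is small, a single fluorine atom giving way to a hydrogen atom, yet the step lies beyond the usual scatter, with the fluoro compound needing less compound for the effect. Nothing measured here explains why this fluoro group makes such a difference.

The compounds shown leave open how a chlorine atom, a methoxy group or a nitrile on this same aromatic carbon would compare with fluoro. They also leave open whether this exchange would give a similar step on a different core.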